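Swapping methoxy for ethoxycarbonyl on a weak growth inhibitor

The source may hold more compounds than are shown below. What is called first, only, known or untested is meant among the compounds shown, and "the series" means these compounds.

Compound 2 `COc1ccc2[nH]c(-c3ccc(Cl)cc3)c(Oc3ccc(Cl)cc3)c2c1` gives 50000 nM in a functional assay on U-373MG ATCC cells (Homo sapiens) for inhibition, read by MTT assay, with a stated time of 72 h; on this read-out higher numbers stand for weaker inhibition of growth and lower numbers for stronger inhibition of growth. Compound 3 `S=C(Sc1c(-c2ccc(Br)cc2)[nH]c2ccccc12)N1CCOCC1` gives 43000 nM, and compound 1 `Clc1ccc(Sc2c(-c3ccc(Br)cc3)[nH]c3ccccc23)cc1` gives 24000 nM; compound 2 thus lies within the scatter of compound 3 and gives a higher number than compound 1, a gap beyond the scatter. Compound 4 `CCOC(=O)c1ccc2[nH]c(-c3ccc(Cl)cc3)c(Oc3ccc(Cl)cc3)c2c1` carries ethoxycarbonyl in place of methoxy on an aromatic carbon. Going by the values given here, no measured step changes anything on that fused ring. Among the compounds with values here, the only measured step, a 1.8-fold higher number from compound 1 to compound 3 (0.25 log units; within the scatter), alters the group on the sulfur and stays within the scatter, so it offers no guide for this change. With nothing pointing either way, compound 4 is expected to show no step beyond the scatter, no change at the digits printed from compound 2 to compound 4 (within the scatter). Compound 4 is therefore estimated at 50000 nM, between 20000 nM and 120000 nM.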

Compound 4, concentration for 50% growth inhibition: 35000 nM
For compound 4 the middle estimate is 1.4-fold (0.15 log units) above the measured one, within the range that was stated.
By their numbers in this assay, from the lowest: compounds 1, 4, 3 and 2 (each within the scatter of the next, the first and the last beyond it).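

Going by these compounds alone, this is the first measured change on the fused ring of the shared core. In this assay, putting ethoxycarbonyl in place of methoxy on this aromatic carbon gives a 1.4-fold lower number from compound 2 to compound 4 (0.15 log units; within the scatter), so this larger group, with its added double bond outside the aromatic rings, brings no change beyond the scatter. No measurement shown offers an explanation for this result.

On these data alone, whether an amine, a carboxylic acid or a longer chain on this carbon would move the number beyond the scatter remains open.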